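Replacing phenyl with fluoro on a bromo compound

A few compounds are considered here, and "the series" means these few. Any claim that something is new, unique, unknown or untested is made for them only; others in the source may bear on it.

In a functional assay on NALM-6 cells (Homo sapiens) for cytotoxicity, read by luminescence and CellTiter-Glo, with a stated time of 3 days (on this read-out higher numbers stand for weaker inhibition and lower numbers for stronger inhibition), compound 2 (`O=C(Nc1cc(C(F)(F)F)cc(C(F)(F)F)c1)c1cc(Br)c(-c2ccccc2)cc1O`) gives 840 nM as its value. Compound 1 (`O=C(Nc1cc(C(F)(F)F)cc(C(F)(F)F)c1)c1cc(Cl)c(F)cc1O`) at 2130 nM lies clearly higher, while compound 3 (`O=C(Nc1cc(C(F)(F)F)cc(C(F)(F)F)c1)c1ccc(-c2ccccc2)cc1O`) at 1580 nM lies within the scatter of compound 2. Compound 4 (`O=C(Nc1cc(C(F)(F)F)cc(C(F)(F)F)c1)c1cc(Br)c(F)cc1O`) is still unmeasured and carries fluoro in place of phenyl on an aromatic carbon. Going by the values given here, the one measured step (a 1.9-fold higher number from compound 2 to compound 3 (0.27 log units; within the scatter)) puts hydrogen in place of bromo, keeps phenyl and stays within the scatter, so it says little here. Compound 1 also has fluoro instead of phenyl, with chloro for bromo, and its 2130 nM is the nearest guide. A higher number is therefore expected (a 2.1-fold higher number from compound 2 to compound 4 (0.33 log units; beyond the scatter)). Compound 4 is estimated at 1800 nM with 900 nM to 3600 nM as its expected range.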

Compound 4, half-maximal inhibitory concentration: 950 nM
Estimate against measurement, compound 4: 1.9-fold (0.28 log units) above; measured number inside the range.
By their numbers in this assay, from the lowest: compounds 2, 4, 3 and 1 (each within the scatter of the next, the first and the last beyond it).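

On the carbon ortho to a bromo group, a whole phenyl ring can give way to a single fluoro with no change beyond the scatter (a 1.1-fold higher number from compound 2 to compound 4 (0.05 log units; within the scatter)), so in this pair the large group is not needed to hold the value. Bromo in place of chloro, with fluoro kept, does register, though modestly (a 2.2-fold lower number from compound 1 to compound 4 (0.35 log units; beyond the scatter)). Still open, on these data alone, is whether an amine or a carboxylic acid on this carbon would hold the value, and whether fluoro there would do the same without the bromo group. No measurement shown here explains either step.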